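Shrinking the Amine Ring on a Thiosemicarbazide

The source may hold more compounds than are shown below. What is called first, only, known or untested is meant among the compounds shown, and "the series" means these compounds.

Measured so far:
compound 1 `N/C(=N\NC(=S)N1CCCC1)c1ccccn1`: 600 nM
compound 2 `Cc1ccnc(/C(N)=N/NC(=S)N2CCCCC2)c1`: 1900 nM

In a functional assay on A-375 cells (Homo sapiens) for cytotoxicity, read by MTT assay, with a stated time of 72 h (a higher number here means a weaker inhibitor, a lower number a stronger inhibitor), compound 1 gives 600 nM. Compound 2 gives 1900 nM in this assay, which is the higher of the two numbers, and its gap to compound 1 is wider than the scatter of repeated measurements, so compound 2 is the weaker of the two measured compounds.

Compound 3 `Cc1ccnc(/C(N)=N/NC(=S)N2CCCC2)c1` has not yet been measured. It differs from compound 2 by a single change: pyrrolidin-1-yl in place of piperidin-1-yl on a thiocarbonyl carbon. Among the compounds with values here, compound 1 also carries a pyrrolidin-1-yl group at that position, yet compound 1 and compound 3 differ elsewhere in the structure, so no measured pair isolates this ring change on its own. The lower number of compound 1 hints that the smaller ring may go with a lower number, but that hint carries another change with it. A step of modest size toward a lower number is expected for compound 3 in this assay, a 1.9-fold lower number from compound 2 to compound 3 (0.28 log units; within the scatter), though none beyond the scatter would not surprise. Compound 3 is therefore estimated at 1000 nM in this assay, within a range of 400 nM to 2500 nM.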

Compound 3, half-maximal inhibitory concentration: 720 nM
Compound 3: middle estimate off by 1.4-fold (0.14 log units), on the high side; low and high end bracket the measured number.
By their numbers in this assay, from the lowest: compounds 1 and 3 (each within the scatter of the next); then compound 2.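

On the thiocarbonyl carbon, pyrrolidin-1-yl in place of piperidin-1-yl can now be read as a single change in this assay, and it gives a 2.6-fold lower number from compound 2 to compound 3 (0.42 log units; beyond the scatter) with nothing else altered, so this ring alone can move the number beyond the scatter. The other pair isolates methyl in place of hydrogen on an aromatic carbon and gives (a 1.2-fold higher number from compound 1 to compound 3 (0.08 log units; within the scatter)), a step within the scatter, so this methyl has no effect that can be told apart from repeat-to-repeat variation in this assay. Among these three compounds, then, the amine ring is the only single change with a step beyond the scatter. Nothing given here explains why the five-membered ring goes with the lower number.

Going by these compounds, the ring step is known only with the methyl present, so whether it holds without that methyl remains open. On these data alone, it is also open whether the lower number would persist with a different amine at the thiocarbonyl carbon, such as the smaller azetidine, a morpholine ring with its added oxygen, or an open-chain dimethylamino group.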